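The source may report more compounds than this note shows. Statements on the series, on what has been measured and on what is new or still open speak of the compounds shown alone.

Working notes on the series.

Compound 3, `Cc1cc(C)c(CN2CCc3c(Cl)cc([C@H](C)CO)c(Cl)c3C2=O)c(=O)[nH]1`, is the reference point here. Among the compounds with values here, in an ADME assay on MDCK cells (Canis lupus familiaris) for permeability, read by LC-MS, with a stated time of 90 min, tested at 2 uM (a lower number here means that the compound crosses the layer more slowly, a higher number that the compound crosses the layer faster), compound 3 gives 12.4 10^-6 cm/s, the second highest of the three numbers so far: close to compound 2, `Cc1cc(C)c(CN2CCc3c(Cl)cc(-c4c(C)noc4C)c(Cl)c3C2=O)c(=O)[nH]1`, which gives 15.7 10^-6 cm/s (a 1.3-fold lower number from compound 2 to compound 3 (0.10 log units; within the scatter)), and clearly separated from compound 1, `Cc1cc(C)c(CN2CCc3c(Cl)cc([C@@H](CO)[C@@H]4CCCO4)c(Cl)c3C2=O)c(=O)[nH]1`, which gives 4.3 10^-6 cm/s.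

Compound 4, `Cc1cc(C)c(CN2CCc3c(Cl)cc([C@H](CO)[C@H]4CCCO4)c(Cl)c3C2=O)c(=O)[nH]1`, differs from compound 3 in one place: a group of 8 heavy atoms (6 carbon, 2 oxygen; one five-membered non-aromatic ring with 1 hetero atom) in place of a group of 4 heavy atoms (3 carbon, 1 oxygen; no ring), on an aromatic carbon. The entering group is the same one carried by compound 1, with both defined stereocentres inverted.

The step that bears on this is the one in the opposite direction, a 2.9-fold higher number from compound 1 to compound 3 (0.46 log units; beyond the scatter); the related step of a 3.7-fold higher number from compound 1 to compound 2 (0.56 log units; beyond the scatter) points the same way. Reversing the first of these, a drop beyond the scatter is expected from compound 3 to compound 4, a 2.5-fold lower number from compound 3 to compound 4 (0.39 log units; beyond the scatter), because compound 1 gives 4.3 10^-6 cm/s in this assay as the only measured carrier of this group. Nothing measured here separates the two stereochemical forms of the group, so the estimate for compound 4 is simply placed near compound 1: 5 10^-6 cm/s, range 2.5 10^-6 cm/s to 10 10^-6 cm/s.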

Compound 4, apparent permeability: 4.1 10^-6 cm/s
Compound 4: middle estimate off by 1.2-fold (0.09 log units), on the high side; measured number inside the range.
By their numbers in this assay, from the lowest: compounds 4 and 1 (each within the scatter of the next); then compounds 3 and 2 (each within the scatter of the next).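

In this assay, the two mirror-image forms of the group on the aromatic carbon do not separate: a 1.0-fold lower number from compound 1 to compound 4 (0.02 log units; within the scatter). The low reading at this position therefore belongs to both forms, and the steps from the smaller 1-(hydroxymethyl)ethyl group and from the aromatic five-membered ring both stand beyond the scatter: a 3.0-fold lower number from compound 3 to compound 4 (0.48 log units; beyond the scatter) and a 3.8-fold lower number from compound 2 to compound 4 (0.58 log units; beyond the scatter). Inverting both stereocentres together therefore has no readable effect here, and the comparison isolates configuration alone: the fact that compounds 1 and 4 differ only in the configuration as drawn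

Still open, going by these compounds, is how a form with only one of the two stereocentres inverted would read. The compounds shown also leave open whether an amine, a carboxylic acid or a longer chain in place of the oxolane ring would give a number nearer that of compound 3 or that of compound 4.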